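The compounds below may be only part of what the source reports. "The series", "measured", "known", "first", "only" and "open" are said of these compounds alone.

Measured so far:
Compound 1, `CC1(C)[C@H]2CC[C@]1(C)N(Cc1cn(-c3ccc(C#N)cc3)nn1)C(=O)C2`: 500 nM
Compound 2, `CC1(C)[C@H]2CC[C@]1(C)N(Cc1cn(-c3cccc(C#N)c3)nn1)C(=O)C2`: 250 nM

Both compounds share one core and differ only in the aromatic ring attached to the ring nitrogen. In a functional assay on SGC-7901 cells (Homo sapiens) for inhibition, read by MTT assay, with a stated time of 24 h (a lower number here means a stronger inhibitor, a higher number a weaker inhibitor), compound 1 gives 500 nM, and in the same assay compound 2 gives 250 nM. On these numbers compound 2 stands beside compound 1: the step of a 2.0-fold lower number from compound 1 to compound 2 (0.30 log units; within the scatter) falls within the scatter, so the two cannot be told apart.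

Compound 3, `CC1(C)[C@H]2CC[C@]1(C)N(Cc1cn(-c3ccc(Br)cc3)nn1)C(=O)C2`, is not yet measured. It differs from compound 2 as follows: 4-bromophenyl in place of 3-cyanophenyl on an aromatic nitrogen. Going by the values given here, the only measured step moves the nitrile from one position to another on the same ring; no measured step replaces a nitrile by a bromine, so none bears directly on this change. Among the compounds with values here, the one step that exists is within the scatter, which gives no reason to expect a large move. The step from compound 2 to compound 3 is therefore estimated at a 1.6-fold higher number from compound 2 to compound 3 (0.20 log units; within the scatter), with a wide range. Compound 3 is expected to give about 400 nM, between 120 nM and 1500 nM.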

Compound 3, half-maximal inhibitory concentration: 450 nM
Compound 3: the middle estimate sits 1.1-fold (0.05 log units) below what was measured; measured number inside the range.
By their numbers in this assay, from the lowest: compounds 2, 3 and 1 (each within the scatter of the next).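

Going by these compounds alone, the cleanest comparison here is the one that changes only the group on the ring: in this assay, bromo in place of cyano on an aromatic carbon gives a 1.1-fold lower number from compound 1 to compound 3 (0.05 log units; within the scatter). A nitrile and a bromine, two quite different groups, therefore cannot be told apart at this spot in this cell test, which the earlier pair, with its nitrile in both compounds, could not show. The other new comparison changes both the group and its place on the ring, and a 1.8-fold higher number from compound 2 to compound 3 (0.26 log units; within the scatter) also leaves the two compounds indistinguishable, so the three aryl groups seen so far do not separate from one another, and no information on any property of these groups is available to say why.

On these data alone, what remains open is whether this flat reading holds for very different groups on the same ring, such as an amine or a carboxylic acid, or for 3-bromophenyl, which would complete the comparison with compound 2. As far as these compounds go, it is also open whether the aromatic ring itself is needed, or whether a longer alkyl chain on that nitrogen would read the same.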